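Coumarin Glycinate Esters: From Thiazolyl to Triazolinyl Amine

The source may report more compounds than this note shows. Statements on the series, on what has been measured and on what is new or still open speak of the compounds shown alone.

Measured compounds:
compound 1 `COc1ccc(NCC(=O)Oc2ccc3c(C)cc(=O)oc3c2)cc1`: 28.8%
compound 2 `Cc1cc(=O)oc2cc(OC(=O)CNc3ccccc3Cl)ccc12`: 23.7%
compound 3 `Cc1cc(=O)oc2cc(OC(=O)CNc3nccs3)ccc12`: 32.3%

In a functional assay on the whole organism (strain Wistar albino) for inhibition, with Rattus norvegicus as the target, read by paw edema, with stated times of 30 min and 4 h, at a dose of 20 mg/kg by the oral route (on this read-out higher numbers stand for more inhibition at the one dose given (going by the name of the read-out) and lower numbers for less inhibition), compound 3 gives the highest of the three numbers, yet its steps to the others are small: a number 3.5 percentage points higher from compound 1 to compound 3 (within the scatter) and a number 8.6 percentage points higher from compound 2 to compound 3 (within the scatter), both within the scatter, as is a number 5.1 percentage points lower from compound 1 to compound 2 (within the scatter). Compound 4 `Cc1cc(=O)oc2cc(OC(=O)CNN3C=NNC3)ccc12` differs from compound 3 in one place: a group of 5 heavy atoms (2 carbon, 3 nitrogen; one five-membered non-aromatic ring with 3 hetero atoms) in place of a group of 5 heavy atoms (3 carbon, 1 nitrogen, 1 sulfur; one five-membered aromatic ring with 2 hetero atoms), on an amine nitrogen. Within the data shown here, no measured step tests this kind of exchange; the three steps that exist all swap one group on the amine nitrogen without moving the number beyond the scatter. The step to compound 4 is therefore expected to be small in either direction, a number 3.3 percentage points lower from compound 3 to compound 4 (within the scatter). Compound 4 is estimated at 29%, ranging from 18% to 40%.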

Compound 4, a percentage reported as inhibition, in the whole organism at one dose (the size of the read-out at that dose, not a potency): 22.2%
Beside the measured number, compound 4's estimate is 6.8 percentage points above it, within the range that was stated.
By their numbers in this assay, from the lowest: compounds 4, 2, 1 and 3 (each within the scatter of the next, the first and the last beyond it).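

In this assay, among these compounds, the change on the amine nitrogen gives the only step at this position that lies beyond the scatter, a number 10.1 percentage points lower from compound 3 to compound 4 (beyond the scatter), and it is a modest one. The same group stays within the scatter of both aryl groups, a number 1.5 percentage points lower from compound 2 to compound 4 (within the scatter) and a number 6.6 percentage points lower from compound 1 to compound 4 (within the scatter), so the position separates only compound 3 from compound 4. Nothing at hand explains this step. Going by these compounds, whether a cyclohexyl group or a simple alkyl amine on this nitrogen would move the number further stays open. So does whether an aromatic triazole would behave like compound 3 or compound 4.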